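Expecting little change from 3-fluorophenyl to 2-bromophenyl

The compounds below may be only part of what the source reports. "The series", "measured", "known", "first", "only" and "open" are said of these compounds alone.

Measured so far in an ADME assay on MT4 cells (Homo sapiens) for cytotoxicity; on this read-out lower numbers stand for higher toxicity in this test and higher numbers for lower toxicity in this test:
- compound 1 `FC(F)(F)c1cccc(NC(=S)Nc2ccc(I)cc2)c1` gives 10000 nM
- compound 2 `Fc1cccc(NC(=S)Nc2cccc(C(F)(F)F)c2)c1` gives 20000 nM

Among the measured compounds shown here, compound 2 stands within the scatter of compound 1, the only other measured compound. Compound 3 `FC(F)(F)c1cccc(NC(=S)Nc2ccccc2Br)c1` differs from compound 2 by 2-bromophenyl in place of 3-fluorophenyl on an amide-type nitrogen, with 2-bromophenyl in place of 3-fluorophenyl on an amide-type nitrogen. For the measured compounds named here, one measured step bears on this, a swap at the same kind of place: a 2.0-fold higher number from compound 1 to compound 2 (0.30 log units; within the scatter). Going by the values given here, with only that small step to go on, the expected move in this assay is a 1.3-fold lower number from compound 2 to compound 3 (0.12 log units; within the scatter), nothing beyond the scatter and with no firm direction. Compound 3 is estimated at 15000 nM with 6000 nM to 40000 nM as the expected range.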

Compound 3, half-maximal cytotoxic concentration: 36000 nM
Compound 3: the middle estimate sits 2.4-fold (0.38 log units) below what was measured; the measured number falls inside the stated range.
By their numbers in this assay, from the lowest: compounds 1, 2 and 3 (each within the scatter of the next, the first and the last beyond it).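

Within this assay, putting 2-bromophenyl on the amide-type nitrogen in place of 3-fluorophenyl gives a 1.8-fold higher number from compound 2 to compound 3 (0.26 log units; within the scatter) and so does not separate these two groups at this place. Set against 4-iodophenyl, the same group gives a 3.6-fold higher number from compound 1 to compound 3 (0.56 log units; beyond the scatter) and is the first step here to pass the scatter, though only modestly. The compounds shown leave open how this read-out responds when the aryl group on this nitrogen carries an amine or a carboxylic acid. Nothing available gives a reason for either step.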